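A few compounds are considered here, and "the series" means these few. Any claim that something is new, unique, unknown or untested is made for them only; others in the source may bear on it.

Measured in a functional assay on HeLa cells (Homo sapiens) for inhibition, read by sulforhodamine B assay; a lower number here means a stronger inhibitor, a higher number a weaker inhibitor:
- compound 1 `O=C1C(Nc2ccc(Br)cc2)=CC(=O)c2c1nc1n2[C@H]2OC[C@@H](O)[C@H]2OC1`: 5220 nM
- compound 2 `Cc1ccc(NC2=CC(=O)c3c(nc4n3[C@H]3OC[C@@H](O)[C@H]3OC4)C2=O)cc1`: 6590 nM

Among the measured compounds shown here, the only measured step is a 1.3-fold higher number from compound 1 to compound 2 (0.10 log units; within the scatter), with methyl in place of bromo on an aromatic carbon. For the measured compounds named here, compound 2 therefore stands within the scatter of the only other measured value, and neither compound can be ranked above the other.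

Compound 3 `COc1ccccc1NC1=CC(=O)c2c(nc3n2[C@H]2OC[C@@H](O)[C@H]2OC3)C1=O` carries 2-methoxyphenyl in place of 4-methylphenyl on an amine nitrogen. Going by the values given here, no measured compound carries a 2-methoxyphenyl, so this change is untested and the evidence is thin. Among the compounds with values here, the one step that bears on it, on the aryl group of the same core, is small: a 1.3-fold higher number from compound 1 to compound 2 (0.10 log units; within the scatter). On that basis, no step beyond the scatter is expected in this assay. The expected step is a 1.1-fold lower number from compound 2 to compound 3 (0.04 log units; within the scatter). The estimate for compound 3 is 6000 nM, with an expected range of 2500 nM to 14000 nM.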

Compound 3, half-maximal inhibitory concentration: 7460 nM
Compound 3: middle estimate off by 1.2-fold (0.09 log units), on the low side; the range from low to high includes it.
By their numbers in this assay, from the lowest: compounds 1, 2 and 3 (each within the scatter of the next).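

In this assay, 2-methoxyphenyl in place of 4-methylphenyl on the amine nitrogen gives a step within the scatter (a 1.1-fold higher number from compound 2 to compound 3 (0.05 log units; within the scatter)), and 2-methoxyphenyl in place of 4-bromophenyl does the same (a 1.4-fold higher number from compound 1 to compound 3 (0.16 log units; within the scatter)). The oxygen-bearing aryl group therefore cannot be separated from either earlier group, and the three aryl groups on this nitrogen cannot be ranked against one another. No supporting measurement bears on this result.

Still open, going by these compounds, is whether any group on this nitrogen moves the number beyond the scatter, for instance a carboxylic acid or a dimethylamino group on the aryl ring, or a cyclohexyl group in place of the aryl ring. Changes to the shared core itself also remain open, as every compound shown carries it unchanged.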